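Removing Both Methyl Groups from Compound 1's Amide Aryl

The compounds below may be only part of what the source reports. "The series", "measured", "known", "first", "only" and "open" are said of these compounds alone.

Measured compounds:
compound 1, `Cc1cc(C)cc(C(=O)NCN2CCC(c3cccc[n+]3[O-])CC2)c1`: 90 nM
compound 2, `Cc1cccc(NC(=O)CN2CCC(c3ccc(O)cn3)CC2)c1`: 3.8 nM
compound 3, `Oc1ccc(N2CCN(Cc3nc4ccccc4[nH]3)CC2)nc1`: 2.4 nM

Three compounds have been run in a functional assay on HEK293 cells for agonist activity at D(4) dopamine receptor (Homo sapiens), read by FLIPR; a lower number here means that less compound is needed, a higher number that more compound is needed for the effect. Compound 1 gives 90 nM, the highest number of the three, and compound 2 and compound 3 both lie far from it, beyond the scatter. The step followed here goes from compound 1 to compound 4, `O=C(NCN1CCC(c2cccc[n+]2[O-])CC1)c1ccccc1`, which is not yet measured in this assay. The change is phenyl in place of 3,5-dimethylphenyl on a carbonyl carbon, leaving the rest of the molecule untouched. Within the data shown here, no measured pair shows this exact change, so the direction rests on judgement alone. A small step, if any, is expected from compound 1 to compound 4, likely no larger than the scatter or a little beyond it, which a 1.7-fold higher number from compound 1 to compound 4 (0.22 log units; within the scatter) expresses. Compound 4 is thus estimated at 150 nM, within 45 nM to 500 nM.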

Compound 4, half-maximal effective concentration: 532 nM
The estimate for compound 4 lay 3.5-fold (0.55 log units) below the measured number; measured number above the stated range.
By their numbers in this assay, from the lowest: compounds 3 and 2 (each within the scatter of the next); then compound 1; then compound 4.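

Phenyl in place of 3,5-dimethylphenyl on a carbonyl carbon gives a 5.9-fold higher number from compound 1 to compound 4 (0.77 log units; beyond the scatter) in this assay and so needs more compound for the effect. The earlier compounds shown here differ in more than one place and could not show this, whereas this pair ties the shift to the two methyl groups alone. No measurement at hand accounts for the step. As far as these compounds go, whether a single methyl group would recover part of the step remains open. So does whether a chlorine or a methoxy group on the ring would match the two methyl groups.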